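Two cytotoxic lactones and an unmeasured unsaturated analogue

A few compounds are considered here, and "the series" means these few. Any claim that something is new, unique, unknown or untested is made for them only; others in the source may bear on it.

Two compounds were tested in a functional assay on PC-12 cells (Rattus norvegicus) for cytotoxicity, read by MTT assay, with a stated time of 24 h, tested at 10 uM; a lower number here means a weaker effect, a higher number a stronger effect of the compound at the concentration tested. Compound 1 `Cc1cc(=O)c(C(C)C)cc2c1CC[C@]2(C)O` gives 75.2% in this assay. Compound 2 `CC1=CC(=O)O[C@@]2(CC(=O)C(C)C)[C@@H](C)CC[C@@H]12` gives 89% in this assay, the higher of the two numbers, and its gap to compound 1 lies beyond the usual scatter. Within the data shown here, no pair differing in a single place has been measured, so no directly comparable step is available.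

Compound 3 `C=C(C)C(=O)C[C@@]12OC(=O)C=C(C)[C@@H]1CC[C@@H]2C` has not been measured. It differs from compound 2 in one place: 1-methylethenyl in place of isopropyl on a carbonyl carbon. Among the measured compounds shown here, with no measured step of this kind to rest on, the expected step of a number 1 percentage points lower from compound 2 to compound 3 (within the scatter) is small, either none beyond the scatter or a slight rise, since compound 2 already stands near the top of the range with 89%. Compound 3 is therefore estimated at 88%, with a plausible range from 72% to 100%.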

Compound 3, a percentage reported as activity, at one concentration (the size of the read-out at that concentration, not a potency): 75.9%
The estimate for compound 3 lay 12.1 percentage points above the measured number; the measured number falls inside the stated range.
By their numbers in this assay, from the lowest: compounds 1 and 3 (each within the scatter of the next); then compound 2.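

Among these compounds, replacing isopropyl with 1-methylethenyl on a carbonyl carbon gives a number 13.1 percentage points lower from compound 2 to compound 3 (beyond the scatter) in this assay, the first single-place comparison in this set, and a lower number here means a weaker effect at the concentration tested. The two groups have the same count of heavy atoms, and the entering group adds one double bond outside aromatic rings, so even this small change in the group at this position shows up in the read-out. No available measurement explains why the number falls.

On these data alone, it remains open how a longer chain, such as n-butyl, or a phenyl ring would read at this position. A single concentration also leaves open whether the step would hold at other concentrations.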